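A few compounds are considered here, and "the series" means these few. Any claim that something is new, unique, unknown or untested is made for them only; others in the source may bear on it.

Measured compounds:
compound 1, `COc1cc(C)cc(-c2c(-c3ccnc(-c4ccc(C(C)=O)cc4)c3)cnn2CC#N)c1`: 2270 nM
compound 2, `COc1cc(C)cc(-c2nn(CC#N)cc2-c2ccc(-c3cccc(C(C)=O)c3)nc2)c1`: 1300 nM
compound 3, `Cc1cc(O)cc(-c2nn(CC#N)cc2-c2ccnc(-c3ccc(Oc4ccccc4)cc3)c2)c1`: 1940 nM

Of the compounds shown here, three built on a shared core have been tested in a functional assay on SW-620 cells (Homo sapiens) for inhibition, read by sulforhodamine B assay, with a stated time of 48 h; a lower number here means a stronger inhibitor of growth, a higher number a weaker inhibitor of growth. Compound 1 has the highest of the three numbers, but its gap to compound 3 and its gap to compound 2 both fall within the usual scatter of repeated measurements, so the three compounds cannot be told apart by these values alone.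

Compound 4, `COc1cc(C)cc(-c2c(-c3ccnc(-c4ccc(N(C)C)cc4)c3)cnn2CC#N)c1`, differs from compound 1 in one place: dimethylamino in place of acetyl on an aromatic carbon, para to a large group. Within the data shown here, no measured pair shows this exact swap, so there is no direct guide to how large the step might be. Since the three measured values all sit within the scatter of one another, and the change is small in atom count, compound 4 is expected to land near compound 1 in this assay, with the step of a 1.1-fold lower number from compound 1 to compound 4 (0.05 log units; within the scatter) expected to stay within the scatter. Compound 4 is therefore estimated at 2000 nM, with a likely range from 700 nM to 6000 nM.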

Compound 4, concentration for 50% growth inhibition: 39.4 nM
The estimate for compound 4 lay 51-fold (1.71 log units) above the measured number, outside the stated range (below it).
By their numbers in this assay, from the lowest: compound 4; then compounds 2, 3 and 1 (each within the scatter of the next).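

In this assay, replacing 4-acetylphenyl with 4-(dimethylamino)phenyl gives a 58-fold lower number from compound 1 to compound 4 (1.76 log units; beyond the scatter). The three earlier values, all within the scatter of one another, gave no sign that a single change could matter this much; this place, on an aromatic carbon para to a large group, clearly does not tolerate every group equally. The two groups have the same heavy-atom count and the same hydrogen-bond donor and acceptor counts, so those counts do not separate them, and no measurement available here explains the step.

On these data alone, it remains open whether a plain amino group or a morpholine ring at this place would match dimethylamino. As far as these compounds go, it is also open whether the same swap on compound 2, which also carries an acetyl, would give a step of similar size.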